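Adding a phenyl to the anilide of compound 1

A few compounds are considered here, and "the series" means these few. Any claim that something is new, unique, unknown or untested is made for them only; others in the source may bear on it.

Measured values in a functional assay on HCT-116 cells (Homo sapiens) for antiproliferative activity, read by MTT assay, with a stated time of 72 h; a higher number here means a weaker inhibitor, a lower number a stronger inhibitor:
- compound 1 `O=C(CCc1cccc2c1B(O)OC2)Nc1ccccc1` gives 350 nM
- compound 2 `O=C(CCc1cccc2c1B(O)OC2)NCc1ccccc1` gives > 100000 nM, which is a limit of the assay and not a number
- compound 3 `O=C(CCc1cccc2c1B(O)OC2)Nc1cccc(I)c1` gives 2300 nM

Compound 1 stands lowest of the two true numbers, so it is the strongest of these three in this assay. Compound 4 `O=C(CCc1cccc2c1B(O)OC2)Nc1ccccc1-c1ccccc1` has not been measured. It differs from compound 1 by phenyl in place of hydrogen on an aromatic carbon.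

For the measured compounds named here, the closest precedent is the addition of iodo in place of hydrogen on an aromatic carbon, a modest step: a 6.6-fold higher number from compound 1 to compound 3 (0.82 log units; beyond the scatter). The swap of phenyl for benzyl on the amide nitrogen was large: an at least 280-fold higher number from compound 1 to compound 2 (2.45 log units; beyond the scatter). Going by the values given here, both measured changes to this part of compound 1 raised the number, though no measured compound carries the added phenyl. A rise larger than the iodo step is therefore expected, but not one as extreme as the benzyl step. The expected step is a 7.1-fold higher number from compound 1 to compound 4 (0.85 log units; beyond the scatter). The estimate for compound 4 is 2500 nM, with an expected range from 500 nM to 20000 nM.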

Compound 4, half-maximal inhibitory concentration: 23000 nM
The estimate for compound 4 lay 9.2-fold (0.96 log units) below the measured number, outside the stated range (above it).
By their numbers in this assay, from the lowest: compound 1; then compound 3; then compound 4. At a limit, above all of these: compound 2.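

In this assay, for the compounds shown here, a phenyl on an aromatic carbon, ortho to a large group, brings a 66-fold higher number from compound 1 to compound 4 (1.82 log units; beyond the scatter) and so costs far more than the only other change to this ring. That other change, a 6.6-fold higher number from compound 1 to compound 3 (0.82 log units; beyond the scatter), differs from the new one in both the group and its place on the ring, so these two steps cannot show which of the two matters more. Nothing given here accounts for the size of the new step.

As far as these compounds go, whether a methyl or a methoxy on that same carbon would keep the number closer to that of compound 1 stays open. So does whether the phenyl would cost as much on another carbon of this ring, or whether an amine on the added phenyl would change the outcome.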